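This account rests on a few compounds, and the source may have more. Where it says the series, first, only, none or still open, it means among the compounds named here.

Working notes on the series.

Of the compounds shown here, three sharing one core have been read in a physicochemical assay, read by spectrophotometry, with a stated time of 6 min; on this read-out lower numbers stand for stronger inhibition and higher numbers for weaker inhibition. Compound 1 `O=C(CCc1nc2ccccc2c(=O)[nH]1)N/N=C/c1ccc(O)c(O)c1` gives 40000000 nM. Compound 3 `COc1cc(/C=N/NC(=O)CCc2nc3ccccc3c(=O)[nH]2)cc(OC)c1OC` gives 55000000 nM. Compound 2 `COc1ccc(/C=N/NC(=O)CCCc2nc3ccccc3c(=O)[nH]2)cc1` gives 180000000 nM, the highest number of the three; the gap to compound 3 and the gap to compound 1 are both beyond the usual scatter, so compound 2 stands as the weakest inhibitor among the measured set.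

The next step is to compound 4 `O=C(CCCc1nc2ccccc2c(=O)[nH]1)N/N=C/c1cc(O)c(O)c(O)c1`, which keeps the longer chain of compound 2 and changes only the aromatic group on the carbon bearing the double bond to nitrogen: 3,4,5-trihydroxyphenyl in place of 4-methoxyphenyl on a carbon with a double bond to nitrogen.

For the measured compounds named here, no measured pair differs in a single place, so the size of this step is not anchored by a directly comparable pair. The direction is suggested by compound 1, whose hydroxylated aryl gives 40000000 nM, a lower number than compound 2. Compound 4 is therefore expected to give a lower number than compound 2, with the step from a 6.0-fold lower number from compound 2 to compound 4 (0.78 log units; beyond the scatter) estimated as a moderate gain beyond the scatter. Compound 4 is estimated at 30000000 nM, within a range of 10000000 nM to 90000000 nM.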

Compound 4, half-maximal inhibitory concentration: 40000000 nM
The estimate for compound 4 lay 1.3-fold (0.12 log units) below the measured number; the range from low to high includes it.
By their numbers in this assay, from the lowest: compounds 1, 4 and 3 (each within the scatter of the next); then compound 2.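

In this assay, for the compounds shown here, 3,4,5-trihydroxyphenyl in place of 4-methoxyphenyl on a carbon with a double bond to nitrogen gives a 4.5-fold lower number from compound 2 to compound 4 (0.65 log units; beyond the scatter) and provides the first step between two compounds that differ in one place. Going by these compounds alone, with the longer chain of compound 2 kept, the number responds to the aromatic group at this position alone, a modest change that lies beyond the scatter and that the earlier compounds could not separate from other differences. Nothing available explains the size or direction of this step.

On these data alone, it remains open whether all three hydroxyl groups are needed, or whether a phenyl group carrying an amine or a carboxylic acid would move the number further. As far as these compounds go, whether the same exchange gives a similar step on the shorter chain of compound 1 also remains open.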